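This account rests on a few compounds, and the source may have more. Where it says the series, first, only, none or still open, it means among the compounds named here.

Three compounds share one core: compound 1, `NC(=S)Nc1cccc(OCCCCCc2ccccc2)c1`, compound 2, `NC(=S)Nc1cccc(OCCCCCOc2ccccc2)c1`, and compound 3, `NC(=S)Nc1cccc(OCCCCCOc2ccccc2-c2ccccc2)c1`. In an ADME assay on Ava5 cells (Homo sapiens) for cytotoxicity (a lower number here means that less compound is tolerated, a higher number that more compound is tolerated), compound 1 gives 22000 nM. Compound 2 reaches only the limit of the measurement, > 50000 nM, so its true value is not known as a number; it stands at the limit of > 50000 nM in this assay, at which 1 of the 2 values shown sits. Within the data shown here, the one measured step, an at least 2.2-fold higher number from compound 1 to compound 2 (0.35 log units; beyond the scatter), runs in the direction of more compound being tolerated, and because it ends at the limit of > 50000 nM in this assay, at which 1 of the 2 values shown sits, its full size is unknown. The change from compound 2 to compound 3 is phenyl in place of hydrogen on an aromatic carbon. Among the measured compounds shown here, no measured step places a phenyl at such a position, so the only guide is that compound 2 already sits at the limit of this assay. The expectation is therefore that compound 3 stays near that limit, with an estimated step of an at least 1.2-fold lower number from compound 2 to compound 3 (0.09 log units; that floor lies within the scatter). The estimate for compound 3 in this assay is 40000 nM, expected to lie between 12000 nM and 100000 nM, with a real chance that again only a limit is reported.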

Compound 3, half-maximal cytotoxic concentration: 13000 nM
The estimate for compound 3 lay 3.1-fold (0.49 log units) above the measured number, and the stated range covers the measured number.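

Among these compounds, this result is the first sign that the aromatic ring at the end of the chain is not free of consequence in this assay. Phenyl in place of hydrogen on an aromatic carbon of this six-membered aromatic ring of carbon only, ortho to a large group, gives an at least 3.8-fold lower number from compound 2 to compound 3 (0.58 log units; beyond the scatter), so less compound is tolerated after this change. Among the compounds shown here, the only earlier step, an at least 2.2-fold higher number from compound 1 to compound 2 (0.35 log units; beyond the scatter), altered the chain end and ran towards more compound being tolerated, whereas this one runs the other way and shows that compound 2 can lose its place at the limit through a single added group. The true size of the new step stays unknown because compound 2 carries a limit and not a number: the limit of > 50000 nM in this assay, at which 1 of the 3 values shown sits.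

The compounds shown leave open whether this change belongs to phenyl itself or would also follow from a smaller group at the same carbon, such as methyl, chlorine or methoxy. They also leave open how phenyl would act on another carbon of that ring, and whether an amine or a carboxylic acid there would give a different result in this assay.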